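The source may report more compounds than this note shows. Statements on the series, on what has been measured and on what is new or still open speak of the compounds shown alone.

Within the data shown here, in a functional assay on the whole organism for inhibition, with Rattus norvegicus as the target (on this read-out higher numbers stand for an effect only at larger amounts of compound and lower numbers for an effect already at smaller amounts), no compound in this small set reaches a number. Compound 1 (`O=C1COCC(=O)N1CCCCN1CCN(c2ncccc2-c2ccccc2)CC1`) stands at > 63 mg/kg as a limit and not a number. Compound 3 (`N#Cc1cccnc1N1CCN(CCCCN2C(=O)CSC2=O)CC1`) stands at > 100 mg/kg as a limit too. Compound 2 (`Cc1cccnc1N1CCN(CCCCN2C(=O)SC3(CCCC3)C2=O)CC1`) stands at > 50 mg/kg as a limit as well, so its place among the three cannot be ranked.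

Compound 4 (`COC(=O)c1cccnc1N1CCN(CCCCN2C(=O)SC3(CCCC3)C2=O)CC1`) carries methoxycarbonyl in place of methyl on an aromatic carbon of the six-membered aromatic ring with 1 nitrogen, ortho to a large group. Among the measured compounds shown here, no measured pair shows what such a swap does. Compound 2 with its limit of > 50 mg/kg gives no number to step from, so no change beyond the scatter is expected in either direction. The estimated size is a step that the limit leaves unreadable from compound 2 to compound 4 and no more than that is expected. In this assay the estimated value for compound 4 is 60 mg/kg with a range from 20 mg/kg to 120 mg/kg expected around it.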

Compound 4, dose for half-maximal effect: 50.2 mg/kg
The estimate for compound 4 lay 1.2-fold (0.08 log units) above the measured number; the measured number falls inside the stated range.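

Among these compounds, compound 2 stands at a limit of > 50 mg/kg and not at a number, so no step from compound 2 to compound 4 can be read in this assay. The compounds shown leave open what methoxycarbonyl in place of methyl does to the dose for half-maximal effect.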